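The compounds below may be only part of what the source reports. "The series", "measured", "known", "first", "only" and "open" are said of these compounds alone.

Measured so far in a functional assay on the whole organism (strain albino) with Mus musculus as the target, at a dose of 100 mg/kg by the intraperitoneal route; on this read-out lower numbers stand for less inhibition and higher numbers for more inhibition at the one dose given (going by the name of the read-out):
compound 1 `O=C(Nc1ccc(I)cc1)Nn1c(-c2ccccc2)nc2ccccc2c1=O` — 60%
compound 2 `O=C(Nc1ccccc1)Nn1c(-c2ccccc2)nc2ccccc2c1=O` — 56%
compound 3 `O=C(Nc1ccc([N+](=O)[O-])cc1)Nn1c(-c2ccccc2)nc2ccccc2c1=O` — 42%

Compound 2 stands second highest of the three. Its gap to compound 1, a number 4 percentage points lower from compound 1 to compound 2 (within the scatter), lies within the scatter, so the two cannot be ordered; its gap to compound 3, a number 14 percentage points lower from compound 2 to compound 3 (beyond the scatter), lies beyond the scatter, as does a number 18 percentage points lower from compound 1 to compound 3 (beyond the scatter).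

Compound 4 `CCc1nc2ccccc2c(=O)n1NC(=O)Nc1ccccc1` differs from compound 2 in one place: ethyl in place of phenyl on an aromatic carbon. All three measured steps change only the group on the anilide ring (iodo, hydrogen, nitro) and leave the shared core untouched; none of them alters the position changed here. For the measured compounds named here, there is therefore no measured step that sets the size or direction of this change, and the expectation can only rest on compound 2 itself.

Compound 4 is expected to give 50%, with a range of 30% to 70%. The step of a number 6 percentage points lower from compound 2 to compound 4 (within the scatter) is the expected change, a small one that is not expected to exceed the scatter with any confidence, the range being wide for lack of a bearing step.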

Compound 4, a percentage reported as inhibition, in the whole organism at one dose (the size of the read-out at that dose, not a potency): 54%
Compound 4: the middle estimate sits 4 percentage points below what was measured; the measured number falls inside the stated range.
By their numbers in this assay, from the lowest: compound 3; then compounds 4, 2 and 1 (each within the scatter of the next).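

At the aromatic carbon between two ring nitrogen atoms, ethyl in place of phenyl gives a number 2 percentage points lower from compound 2 to compound 4 (within the scatter) in this assay. For the compounds shown here, the aromatic ring at this position can therefore be replaced by a small chain with no ring without a step beyond the scatter in this read-out, whereas the earlier steps showed only changes on the anilide ring. No measurement on hand offers an explanation for this result.

On these data alone, what a butyl chain, an amine or a carboxylic acid at this carbon would do remains open. Also open, as far as these compounds go, is whether the step seen with nitro in place of hydrogen on the anilide ring, a number 14 percentage points lower from compound 2 to compound 3 (beyond the scatter), would carry over to a compound that has ethyl at this position.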